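This account rests on a few compounds, and the source may have more. Where it says the series, first, only, none or still open, it means among the compounds named here.

Of the compounds shown here, two of one family have been tested in a functional assay on A2780 cells (Homo sapiens) for inhibition, read by MTT assay, with a stated time of 72 h; a lower number here means a stronger inhibitor of growth, a higher number a weaker inhibitor of growth. Compound 1, with structure `N#C/C(=C\c1ccc[nH]1)C(=O)NCc1ccc(Cl)c(Cl)c1`, gives > 50000 nM, which is a limit of the assay rather than a number. Compound 2, with structure `COc1ccc(CNC(=O)/C(C#N)=C/c2ccc(C)o2)cc1`, gives 60000 nM in this assay. Among the compounds with values here, of the two results, that is the only actual number; the other one sits at the limit of > 50000 nM in this assay, at which 1 of the 2 values shown sits. Compound 2 therefore stands as the single measured point, and it is a weak inhibitor of growth. Compound 3, with structure `COc1ccc(CNC(=O)/C(C#N)=C/c2ccc(Br)o2)cc1`, has not yet been measured. It differs from compound 2 in one place: bromo in place of methyl on an aromatic carbon. Within the data shown here, no step between two measured compounds is available to show what such an exchange does, so the expected step of no change at the digits printed from compound 2 to compound 3 (within the scatter) is none beyond the scatter, with the result remaining weak. Compound 3 is estimated at 60000 nM, with a range from 25000 nM to 150000 nM, and there is a fair chance that this assay reports only a limit for it.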

Compound 3, concentration for 50% growth inhibition: 12000 nM
The estimate for compound 3 lay 5.0-fold (0.70 log units) above the measured number; the measured number lies below the stated range.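

In this assay the exchange of 5-methylfuran-2-yl for 5-bromofuran-2-yl gives a 5.0-fold lower number from compound 2 to compound 3 (0.70 log units; beyond the scatter) and so marks this aromatic carbon, next to the ring oxygen, as a place where a single replacement moves growth inhibition beyond the scatter. The earlier compounds shown here could not show this, since they offered no step at all, and here the change adds no ring, no hydrogen-bond donor or acceptor and no net charge. The step is modest, and nothing shown here explains why bromo gives a lower number than methyl at this place.

A single exchange cannot tell whether bromo is unusual at this carbon or whether chloro, an amine or a carboxylic acid in the same place would give a similar number. Within the data shown here, compound 1 differs from compound 2 in more than one place and so gives no step, which leaves open whether the same exchange would have a similar effect with a different group on the amide nitrogen.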